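A few compounds are considered here, and "the series" means these few. Any claim that something is new, unique, unknown or untested is made for them only; others in the source may bear on it.

Working notes on the series. In an ADME assay on microsomes from liver (Rattus norvegicus) for metabolic stability, read by LC-MS, using NADPH, with stated times of 10 min and 60 min (a lower number here means that the compound disappears faster, a higher number that the compound lasts longer), compound 1 `CCN1CCN(c2cc(CN(C)[C@H]3CCCc4cccnc43)nc(C)n2)CC1` gives 0.019 h, and compound 2 `Cc1nc(CN(C)[C@H]2CCCc3cccnc32)cc(N2CCN(C)[C@@H](C)C2)n1` gives 0.0267 h. Compound 3 `Cc1nc(CN(C)[C@H]2CCCc3cccnc32)cc(N2CCN(C)[C@H](C)C2)n1` has only a limit and no number, < 0.0167 h. Compound 4 `Cc1nc(CN(C)[C@H]2CCCc3cccnc32)cc(N2C[C@@H](C)N(C)[C@@H](C)C2)n1` differs from it as follows: methyl in place of hydrogen on a saturated ring carbon. This is methyl in place of hydrogen on a saturated ring carbon, turning 3,4-dimethylpiperazin-1-yl into 3,4,5-trimethylpiperazin-1-yl. The closest measured steps are a 1.4-fold higher number from compound 1 to compound 2 (0.15 log units; within the scatter) and an at least 1.5-fold lower number from compound 2 to compound 3 (0.20 log units; that floor lies within the scatter), the second coming with the fact that compounds 2 and 3 differ only in the configuration as drawn. Neither is shown beyond the scatter, so no clear move in this assay is expected. The expected change is an at least 1.1-fold higher number from compound 3 to compound 4 (0.05 log units; that floor lies within the scatter), which is not expected to exceed the scatter. For compound 4 the estimate is 0.019 h, with an expected range of 0.012 h to 0.04 h.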

Compound 4, half-life: < 0.0167 h
Compound 4 ended at the assay's limit; the forecaster's own chance of this, stated with the estimate: 40%; at least 1.1-fold (0.05 log units) between middle value and limit.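

Compound 4, like compound 3, ends at a limit in this assay, and the step between them cannot be read: the limit of < 0.0167 h in this assay, at which 2 of the 4 values shown sit. Adding this methyl to the 3,4-dimethylpiperazin-1-yl group therefore gives no measurable number. The readable steps are an at least 1.5-fold lower number from compound 2 to compound 4 (0.20 log units; that floor lies within the scatter) and an at least 1.1-fold lower number from compound 1 to compound 4 (0.05 log units; that floor lies within the scatter), and neither is shown beyond the scatter.

As far as these compounds go, whether the added methyl moves the half-life at all stays open, with compound 3 and compound 4 both at the limit. Also open, from the compounds shown here alone, is how a hydroxyl or an ethyl on this saturated ring carbon would read in this assay.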